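The source may hold more compounds than are shown below. What is called first, only, known or untested is meant among the compounds shown, and "the series" means these compounds.

Compound 1, `COc1cc(-c2ccccc2)cc(O)c1O`: > 10000 nM
Compound 2, `COc1cc(OC)cc(-c2ccccc2O)c1`: > 10000 nM

Of the compounds shown here, two have been tested in a functional assay on SK-MEL-2 cells (Homo sapiens) for cytotoxicity, read by sulforhodamine B assay; on this read-out higher numbers stand for weaker inhibition and lower numbers for stronger inhibition. In this assay compound 1 gives > 10000 nM, which is a limit of the assay rather than a number. Compound 2 in this assay likewise gives > 10000 nM, again a limit. Among the measured compounds shown here, both values therefore rest at the limit of > 10000 nM in this assay, at which 2 of the 2 values shown sit, so compound 1 stands at the limit with no number of its own, and no step between measured compounds can be read from the pair.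

Compound 3, `COc1cc(-c2ccccc2)cc(OC)c1O`, is the next compound to be placed in this assay. Its difference from compound 1 is methyl in place of hydrogen on an oxygen on an aromatic ring. For the measured compounds named here, there is no measured step in this assay that involves such a change, so the expectation for compound 3 rests on compound 1 alone, whose value > 10000 nM is a limit. The step that the estimate means, a step that the limit leaves unreadable from compound 1 to compound 3, is expected to be none beyond the scatter. Compound 3 is accordingly expected to give 15000 nM in this assay, within a range from 5000 nM to 50000 nM, with a strong chance that the assay again reports only a limit.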

Compound 3, half-maximal inhibitory concentration: > 10000 nM
Compound 3: a limit, no number (the forecaster's own chance of this, stated with the estimate: 80%); the middle value lies beyond the limit too.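

In this assay, among the compounds shown here, compound 3 gives > 10000 nM, which is a limit and not a number, so no step from compound 1 to compound 3 can be read. All values shown stand at the same point: the limit of > 10000 nM in this assay, at which 3 of the 3 values shown sit. The compounds shown leave open whether methyl in place of hydrogen on an oxygen on an aromatic ring changes the read-out at all.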